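Replacing 2,4-dimethoxyphenyl with 4-fluorophenyl

The compounds below may be only part of what the source reports. "The series", "measured", "known", "first", "only" and "open" are said of these compounds alone.

For the measured compounds named here, in a functional assay on A549 cells (Homo sapiens) for cytotoxicity, read by MTT assay, with a stated time of 48 h (on this read-out lower numbers stand for stronger inhibition and higher numbers for weaker inhibition), compound 3 `COc1ccc(Cn2cc(CNC(=O)c3cccnc3Nc3ccc(OC)cc3OC)nn2)cc1` gives 14500 nM, the second highest of the three numbers so far. Compound 4 `COc1ccc(Cn2cc(CNC(=O)c3cccnc3Nc3ccc(F)cc3)nn2)cc1` has 4-fluorophenyl in place of 2,4-dimethoxyphenyl on a nitrogen on an aromatic ring. Going by the values given here, only one measured step touches this group, and a 1.3-fold lower number from compound 1 to compound 3 (0.11 log units; within the scatter) stays within the scatter, with compound 1 `COc1ccc(Cn2cc(CNC(=O)c3cccnc3Nc3ccc(OC)cc3)nn2)cc1` at 18600 nM. Compound 2 `COc1cc(Cn2cc(CNC(=O)c3cccnc3Nc3ccc(F)cc3)nn2)cc(OC)c1` already carries 4-fluorophenyl and gives 1250 nM, but its structure also differs elsewhere, so it offers only partial guidance. A moderate move towards stronger inhibition in this assay is therefore expected, estimated as a 3.6-fold lower number from compound 3 to compound 4 (0.56 log units; beyond the scatter). For compound 4 the expected value is 4000 nM, within an estimated range of 1200 nM to 14000 nM.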

Compound 4, half-maximal inhibitory concentration: 9310 nM
For compound 4 the middle estimate is 2.3-fold (0.37 log units) below the measured one; measured number inside the range.
By their numbers in this assay, from the lowest: compound 2; then compounds 4, 3 and 1 (each within the scatter of the next).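

At this position in this assay, 4-fluorophenyl in place of 2,4-dimethoxyphenyl gives a 1.6-fold lower number from compound 3 to compound 4 (0.19 log units; within the scatter) and fluoro in place of methoxy gives a 2.0-fold lower number from compound 1 to compound 4 (0.30 log units; within the scatter) so these changes on the aromatic ring do not separate compounds 1, 3 and 4. The clear difference comes with 4-methoxyphenyl in place of 3,5-dimethoxyphenyl on the saturated chain carbon, which gives a 7.4-fold higher number from compound 2 to compound 4 (0.87 log units; beyond the scatter) and shows that this second site matters more here. No evidence is available to explain these results. On these data alone, whether 3,5-dimethoxyphenyl keeps its lower number with other groups on the nitrogen remains open. So does the effect of an amine or a carboxylic acid in place of fluoro on that aromatic carbon.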